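The source may report more compounds than this note shows. Statements on the series, on what has been measured and on what is new or still open speak of the compounds shown alone.

The measured compounds in this set:

compound 1 `CN(C[C@H]1Cc2c(cccc2N2CCN(Cc3ccccn3)CC2)CN1)[C@H]1CCCc2cccnc21` — 4.2%
compound 2 `CN(C[C@H]1Cc2c(cccc2N2CCN(C3COC3)CC2)CN1)[C@H]1CCCc2cccnc21` — 83.1%
compound 3 `CN1CCN(c2cccc3c2C[C@H](CN(C)[C@H]2CCCc4cccnc42)N(C)C3)CC1` — 83.3%

In an ADME assay on microsomes from liver (Homo sapiens) for metabolic stability, read by LC-MS, with a stated time of 10 min (on this read-out higher numbers stand for a more stable compound and lower numbers for a less stable compound), compound 2 stands second highest of the three numbers. Its nearest neighbour is compound 3, whose value lies within the scatter of that of compound 2, so the two cannot be ordered. The furthest is compound 1, which lies lower, beyond the scatter.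

Compound 4 `C[C@@H]1CN(c2cccc3c2C[C@H](CN(C)[C@H]2CCCc4cccnc42)NC3)C[C@H](C)N1C` is the next compound to be read in this assay. It differs from compound 2 as follows: 3,4,5-trimethylpiperazin-1-yl in place of 4-(oxetan-3-yl)piperazin-1-yl on an aromatic carbon.

Among the measured compounds shown here, only one measured step exists, a number 78.9 percentage points higher from compound 1 to compound 2 (beyond the scatter), and it concerns a change on the amine nitrogen in a ring, not an exchange of the whole group on the aromatic carbon. For the measured compounds named here, no measured step covers the change from compound 2 to compound 4. What the numbers do show is that compound 2 and compound 3, which carry different groups at that position, give values within the scatter of each other.

On that basis the step of a number 13.1 percentage points lower from compound 2 to compound 4 (beyond the scatter) is expected to stay within the scatter, with no direction to be trusted. Compound 4 is therefore estimated at 70%, in a range from 40% to 92%.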

Compound 4, percent of the compound remaining: 24.6%
Compound 4: middle estimate off by 45.4 percentage points, on the high side; the whole stated range lies above it.
By their numbers in this assay, from the lowest: compound 1; then compound 4; then compounds 2 and 3 (each within the scatter of the next).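

In this assay, the group on the aromatic carbon proves not to be indifferent: a number 58.5 percentage points lower from compound 2 to compound 4 (beyond the scatter), a large change, even though a six-membered ring with two hetero atoms stays attached there. Read with a number 78.9 percentage points higher from compound 1 to compound 2 (beyond the scatter), this makes two single-place exchanges in the group on that carbon that each move the read-out beyond the scatter, one upward and one downward, so stability in this set responds strongly to what the piperazine carries. No measurement bearing on the reason for the fall from compound 2 to compound 4 accompanies these numbers.

The exchange removes the oxetan-3-yl group and brings in three methyl groups and two defined stereocentres in one step, so the compounds shown leave open which of these differences accounts for the fall. A 3,5-dimethylpiperazin-1-yl group with oxetan-3-yl on its nitrogen, or a plain 4-methylpiperazin-1-yl group on the core of compound 2, would separate the ring methyl groups from the group on the nitrogen.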